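This account rests on a few compounds, and the source may have more. Where it says the series, first, only, none or still open, it means among the compounds named here.

Measured so far in a functional assay on NCI/ADR cells (Homo sapiens) for inhibition, read by sulforhodamine B assay, with a stated time of 48 h; on this read-out lower numbers stand for stronger inhibition of growth and higher numbers for weaker inhibition of growth:
compound 1 `O=C1C=COC(/C=C/c2ccccc2)C1` — 105 uM
compound 2 `O=C1C=COC(/C=C/c2ccc(C(F)(F)F)cc2)C1` — 51.6 uM
compound 3 `COc1ccc(/C=C/C2CC(=O)C=CO2)cc1` — 239 uM

Compound 3 stands highest of the three numbers: a 2.3-fold higher number from compound 1 to compound 3 (0.36 log units; beyond the scatter), and a 4.6-fold higher number from compound 2 to compound 3 (0.67 log units; beyond the scatter). Compound 4 `COc1ccc(/C=C/C2CC(=O)C=CO2)cc1OC` is the next step from compound 3; the change is methoxy in place of hydrogen on an aromatic carbon. Among the compounds with values here, the one measured step of the same kind is a 2.3-fold higher number from compound 1 to compound 3 (0.36 log units; beyond the scatter). The other two steps, a 2.0-fold lower number from compound 1 to compound 2 (0.31 log units; beyond the scatter) and a 4.6-fold higher number from compound 2 to compound 3 (0.67 log units; beyond the scatter), involve trifluoromethyl and bear only indirectly on a second methoxy. Within the data shown here, on that basis a further modest rise in the number in this assay is expected, though with only one precedent the size is uncertain. The expected step is a 1.6-fold higher number from compound 3 to compound 4 (0.20 log units; within the scatter). Compound 4 is therefore estimated at 380 uM, within a range of 150 uM to 900 uM.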

Compound 4, concentration for growth inhibition (reported as GI): 146 uM
The estimate for compound 4 lay 2.6-fold (0.42 log units) above the measured number, outside the stated range (below it).
By their numbers in this assay, from the lowest: compound 2; then compounds 1, 4 and 3 (each within the scatter of the next, the first and the last beyond it).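

In this assay, methoxy in place of hydrogen on the aromatic carbon ortho to a methoxy group and meta to a group of 9 heavy atoms gives a 1.6-fold lower number from compound 3 to compound 4 (0.21 log units; within the scatter). The same kind of change gave a 2.3-fold higher number from compound 1 to compound 3 (0.36 log units; beyond the scatter), so the rise beyond the scatter at the first methoxy does not recur at this position. No supporting data are available to explain this result.

Open, as far as these compounds go, is whether a hydroxyl group or an amine on this carbon would shift the number beyond the scatter. Also open, from the compounds shown here alone, is whether a longer chain, such as ethoxy, would do so.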